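What a nitro group may do to compound 2

A few compounds are considered here, and "the series" means these few. Any claim that something is new, unique, unknown or untested is made for them only; others in the source may bear on it.

Measured so far (a functional assay on UACC-62 cells (Homo sapiens) for cytotoxicity, read by MTT assay, with a stated time of 6 days; a lower number here means a stronger inhibitor, a higher number a weaker inhibitor):
- compound 1 (`CC(=O)N[C@@H](CSC(=O)Nc1ccccc1F)C(=O)O`) gives > 200000 nM as a limit
- compound 2 (`CC(=O)N[C@@H](CSC(=O)Nc1ccccc1Cl)C(=O)O`) gives > 200000 nM as a limit
- compound 3 (`CC(=O)N[C@@H](CSC(=O)Nc1ccccc1)C(=O)O`) gives 125000 nM as a number

Compound 2 has no number of its own, only a limit, and compound 1 shares that position (the limit of > 200000 nM in this assay, at which 2 of the 3 values shown sit). Compound 4 (`CC(=O)N[C@@H](CSC(=O)Nc1ccc([N+](=O)[O-])cc1Cl)C(=O)O`) is compound 2 with one addition: nitro in place of hydrogen on an aromatic carbon. The new group stands meta to the chloro group and para to a large group.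

Going by the values given here, three measured steps bear on this, all from changes to a single group on the aromatic ring. The first is an at least 1.6-fold lower number from compound 2 to compound 3 (0.20 log units; that floor lies within the scatter) and the second is an at least 1.6-fold lower number from compound 1 to compound 3 (0.20 log units; that floor lies within the scatter). The third is a step that the two limits leave unreadable from compound 1 to compound 2. None of them places a group where the nitro enters, so they offer only a loose guide. They show no firm change, and the single number among these compounds lies close to the limit. A small move in this assay toward a lower number is therefore expected, or none beyond the scatter. The estimate means an at least 1.3-fold lower number from compound 2 to compound 4 (0.12 log units; that floor lies within the scatter) as the expected step. Compound 4 is expected at 150000 nM (estimated range 50000 nM to 400000 nM). It could also return only a limit.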

Compound 4, half-maximal inhibitory concentration: > 200000 nM
Compound 4: only a limit was reported (the forecaster's own chance of this, stated with the estimate: 45%); middle value at least 1.3-fold (0.12 log units) away from the limit.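

Compound 2 and compound 4 both return only a limit in this assay, so no step between them can be read, and compound 4 joins the compounds held at that limit: the limit of > 200000 nM in this assay, at which 3 of the 4 values shown sit.

The compounds shown leave open whether nitro in place of hydrogen on an aromatic carbon moves the number at all, and in which direction.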